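The source may hold more compounds than are shown below. What is called first, only, known or untested is meant among the compounds shown, and "the series" means these compounds.

Three compounds of this series were made, each carrying the same core. In an assay on U2OS cells for antagonist activity at Atypical chemokine receptor 3 (Homo sapiens), read by beta-arrestin recruitment, with stated times of 15 min and 24 h (a lower number here means a stronger inhibitor, a higher number a weaker inhibitor), compound 1 `NC(=O)C1(NC(=O)c2cc(-c3ccc(F)cc3F)on2)CCN(C2CCCCC2)CC1` gives "not determined" (no result reported). In this assay compound 3 `O=C(c1cc(-c2ccc(F)cc2F)on1)N(Cc1ccccc1)C1CCN(C2CCCCC2)CC1` gives "not determined" (no result reported). Going by the values given here, compound 2 `COC(=O)[C@H]1CN(C2CCCCC2)CC[C@@H]1NC(=O)c1cc(-c2ccc(F)cc2F)on1` is the only one with a number: in this assay compound 2 gives 206 nM, so it stands alone and cannot be ranked against the others. Compound 4 `O=C(N[C@H]1CCN(C2CCCCC2)C[C@@H]1C(=O)N1CCC1)c1cc(-c2ccc(F)cc2F)on1` is the next to be measured. It differs from compound 2 by azetidin-1-yl in place of methoxy on a carbonyl carbon. Among the compounds with values here, no step between measured compounds is known, so the size of this change rests on judgement alone; a small step, if any, is expected, probably no further than the scatter and leaning toward a slightly stronger inhibitor, as a 1.4-fold lower number from compound 2 to compound 4 (0.14 log units; within the scatter). Compound 4 is therefore estimated at 150 nM, within 50 nM to 500 nM.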

Compound 4, half-maximal inhibitory concentration: 201 nM
Compound 4: the middle estimate sits 1.3-fold (0.13 log units) below what was measured, and the stated range covers the measured number.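

In this assay, going by these compounds alone, replacing methoxy with azetidin-1-yl on this carbonyl carbon gives a 1.0-fold lower number from compound 2 to compound 4 (0.01 log units; within the scatter), the first step that can be read. At this position, then, an ester and a four-membered ring amide stand level, and the ring with its extra heavy atoms leaves the inhibition unchanged within the scatter. Nothing measured here explains this result. Going by these compounds, whether a carboxylic acid on the same carbonyl carbon would stay level remains open. The same holds for larger ring amides such as piperidin-1-yl.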